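Working notes: replacing one group on the shared core

The compounds below may be only part of what the source reports. "The series", "measured", "known", "first", "only" and "open" are said of these compounds alone.

compound 1 `CCOC(=O)C1=C(N/N=C(\c2ccc([N+](=O)[O-])cc2)N2CCN(c3ccc(F)cc3)CC2)Nc2[nH]nc(C)c2C1c1ccc(N(C)C)cc1` gives 90200 nM in a functional assay on HepG2 cells (Homo sapiens) for inhibition, read by MTT assay, with a stated time of 48 h; a higher number here means a weaker inhibitor, a lower number a stronger inhibitor
compound 2 `CCOC(=O)C1=C(N/N=C(/C#N)C(=O)OCC)Nc2[nH]nc(C)c2C1c1ccc(N(C)C)cc1` gives 46400 nM in this assay
compound 3 `CCOC(=O)C1=C(N/C=N/c2ncc(-c3ccccc3)s2)Nc2[nH]nc(C)c2C1c1ccc(N(C)C)cc1` gives 9790 nM in this assay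

Compound 2 (46400 nM) holds the second highest of the three numbers. Its gap to compound 1 (90200 nM) lies within the scatter, so these two cannot be told apart. Compound 3 (9790 nM) gives a lower number than compound 2, and that gap lies beyond the scatter.

Compound 4 `CCOC(=O)C1=C(N/N=C(/Cl)c2ccc([N+](=O)[O-])cc2)Nc2[nH]nc(C)c2C1c1ccc(N(C)C)cc1` keeps the shared core of compound 2 and differs only in the group on an amine nitrogen (a group of 12 heavy atoms (7 carbon, 2 nitrogen, 2 oxygen, 1 chlorine; one six-membered aromatic ring of carbon only) in place of a group of 9 heavy atoms (5 carbon, 2 nitrogen, 2 oxygen; no ring), on an amine nitrogen). Within the data shown here, no measured pair differs in one place alone, so the size of this change cannot be read directly from the series. Among the measured compounds shown here, the three measured compounds differ in this same region, and they give the only available guide. Compound 3 (9790 nM) and compound 1 (90200 nM) mark the ends of that spread. Nothing in the three numbers points firmly in either direction, so no step beyond the scatter is expected in this assay. The expected change is small (a 1.5-fold lower number from compound 2 to compound 4 (0.19 log units; within the scatter)). For compound 4 the estimate is 30000 nM (expected range 10000 nM to 90000 nM).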

Compound 4, half-maximal inhibitory concentration: 55500 nM
Compound 4: the middle estimate sits 1.9-fold (0.27 log units) below what was measured; the range from low to high includes it.
By their numbers in this assay, from the lowest: compound 3; then compounds 2, 4 and 1 (each within the scatter of the next).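

In this assay the series now has its first single-place step, a 1.2-fold higher number from compound 2 to compound 4 (0.08 log units; within the scatter), and it lies within the scatter. At this position, on an amine nitrogen whose other neighbour is a double-bonded ring carbon, the group of 9 heavy atoms with no ring and the group of 12 heavy atoms with one six-membered aromatic ring of carbon only cannot be told apart, so neither the added ring and chlorine nor the lost triple bond gives a readable change in this assay. Nothing available explains why the step stays this small.

Going by these compounds, whether a carboxylic acid or a longer alkyl chain on this amine nitrogen would move the number beyond the scatter remains open. Among these compounds, compound 3 gives 9790 nM in this assay, but no single-place step links it to any other compound, and the same holds for compound 1, so what in either structure goes with its number cannot be read.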